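Swapping Nitro for Carbamoyl on the Benzamide Ring

This account rests on a few compounds, and the source may have more. Where it says the series, first, only, none or still open, it means among the compounds named here.

Measured so far in an assay on HEK293 cells for displacement of a labelled ligand from metabotropic glutamate receptor 5 (Rattus norvegicus); on this read-out lower numbers stand for stronger inhibition and higher numbers for weaker inhibition:
Compound 1 `O=C(Nc1cc(-c2ccccc2)nn1-c1ccccc1)c1ccccc1` gives 4180 nM.
Compound 2 `COc1ccc(C(=O)Nc2cc(-c3ccccc3)nn2-c2ccccc2)cc1` gives 420 nM.
Compound 3 `O=C(Nc1cc(-c2ccccc2)nn1-c1ccccc1)c1ccc([N+](=O)[O-])cc1` gives 250 nM.

Compound 3 holds the lowest number of the three; compound 2 lies within the scatter of it, while compound 1 is far off: a 17-fold lower number from compound 1 to compound 3 (1.22 log units; beyond the scatter) and a 1.7-fold lower number from compound 2 to compound 3 (0.23 log units; within the scatter). Compound 4 `NC(=O)c1ccc(C(=O)Nc2cc(-c3ccccc3)nn2-c2ccccc2)cc1` alters compound 3 in one place: carbamoyl in place of nitro on an aromatic carbon, on an aromatic carbon of a six-membered aromatic ring of carbon only, para to a large group. Two kinds of step inform this. Adding a group at that carbon mattered greatly (a 10-fold lower number from compound 1 to compound 2 (1.00 log units; beyond the scatter)), whereas exchanging one group for another there did not (a 1.7-fold lower number from compound 2 to compound 3 (0.23 log units; within the scatter)). Carbamoyl has no measured precedent here, so a somewhat higher number is expected for compound 4: a 2.8-fold higher number from compound 3 to compound 4 (0.45 log units; beyond the scatter). The estimate for compound 4 in this assay is 700 nM, within 150 nM to 3500 nM.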

Compound 4, inhibition constant: > 10000 nM
Compound 4: a limit, no number; the forecaster's own chance of this, stated with the estimate: 5%; middle value at least 14-fold (1.15 log units) from the limit.
By their numbers in this assay, from the lowest: compounds 3 and 2 (each within the scatter of the next); then compound 1. At a limit, above all of these: compound 4.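

In this assay compound 4 gives a limit and not a number: the limit of > 10000 nM in this assay, at which 1 of the 4 values shown sits.

So exchanging one group for another at this carbon can matter greatly: methoxy and nitro lie within the scatter of each other, yet carbamoyl gives an at least 40-fold higher number from compound 3 to compound 4 (1.60 log units; beyond the scatter) and an at least 23-fold higher number from compound 2 to compound 4 (1.37 log units; beyond the scatter). A group here can also do worse than plain hydrogen, with an at least 2.3-fold higher number from compound 1 to compound 4 (0.37 log units; beyond the scatter).

The compounds shown leave open whether this loss is specific to carbamoyl or would also appear with a carboxylic acid, an amine or a nitrile at this carbon.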